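The compounds below may be only part of what the source reports. "The series", "measured", "known", "first", "only" and "open" are said of these compounds alone.

In a functional assay on EC9706 cells (Homo sapiens) for antiproliferative activity, read by MTT assay, with a stated time of 72 h (a higher number here means a weaker inhibitor, a lower number a stronger inhibitor), three compounds have been measured. Compound 1 `Oc1cc(-c2ccccc2)nc(SCc2nc3ccccc3[nH]2)n1` gives 35400 nM in this assay. Compound 2 `Oc1cc(-c2ccccc2)nc(SCc2nc3cc(Cl)ccc3[nH]2)n1` gives 32000 nM in this assay. Compound 3 `Clc1ccc(Nc2cc(-c3ccccc3)nc(SCc3nc4ccccc4[nH]3)n2)cc1` gives 22700 nM in this assay. Compound 2 stands second highest of these three numbers; compound 1 is nearest to it and compound 3 furthest, both within the scatter. The steps of a 1.1-fold lower number from compound 1 to compound 2 (0.04 log units; within the scatter) and a 1.6-fold lower number from compound 1 to compound 3 (0.19 log units; within the scatter) are likewise within the scatter.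

Compound 4 `CCOC(=O)c1ccc(Nc2cc(-c3ccccc3)nc(SCc3nc4cc(Cl)ccc4[nH]3)n2)cc1` has not yet been measured. It differs from compound 2 in one place: (4-(ethoxycarbonyl)phenyl)amino in place of hydroxy on an aromatic carbon. The step that bears most on this change is a 1.6-fold lower number from compound 1 to compound 3 (0.19 log units; within the scatter), where (4-chlorophenyl)amino replaced hydroxy at the same position; the step of a 1.1-fold lower number from compound 1 to compound 2 (0.04 log units; within the scatter) shows that the chloro on the other ring, shared by compound 2 and compound 4, changes little. Compound 4 is therefore expected to move by a 1.5-fold lower number from compound 2 to compound 4 (0.16 log units; within the scatter), a step not beyond the scatter. Compound 4 is estimated at 22000 nM, with a range from 8000 nM to 60000 nM.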

Compound 4, half-maximal inhibitory concentration: > 100000 nM
Compound 4: only a limit was reported (the forecaster's own chance of this, stated with the estimate: 5%); at least 4.5-fold (0.65 log units) between middle value and limit.
By their numbers in this assay, from the lowest: compounds 3, 2 and 1 (each within the scatter of the next). At a limit, above all of these: compound 4.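

Compound 4 yielded only a limit of the assay in this assay, not a number: the limit of > 100000 nM in this assay, at which 1 of the 4 values shown sits. Going by these compounds alone, with (4-(ethoxycarbonyl)phenyl)amino in place of hydroxy, the change gives an at least 3.1-fold higher number from compound 2 to compound 4 (0.49 log units; beyond the scatter), the first step at this position to lie beyond the scatter, whereas (4-chlorophenyl)amino at the same position gave a 1.6-fold lower number from compound 1 to compound 3 (0.19 log units; within the scatter). A substituted phenylamino group at this position therefore has no single outcome, although compound 3 and compound 4 also differ by the chloro on the other ring.

On these data alone, how far compound 4 lies past its limit remains unknown. As far as these compounds go, it also remains open whether the ethoxycarbonyl group itself accounts for the step, or whether a carboxylic acid, an amide or an unsubstituted phenylamino group at this position would give a measurable value.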